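Replacing the Trifluoromethylphenyl Urea Substituent

This account rests on a few compounds, and the source may have more. Where it says the series, first, only, none or still open, it means among the compounds named here.

Compound 1 `CCN(CC)CCn1cnnc1-c1cc(Oc2ccc(NC(=O)Nc3ccc(Cl)c(C(F)(F)F)c3)cc2F)ccn1`: 900 nM in a functional assay on HT-29 cells (Homo sapiens) for antiproliferative activity, read by MTT assay, with a stated time of 72 h; a higher number here means a weaker inhibitor, a lower number a stronger inhibitor.
Compound 2 `CCN(CC)CCn1cnnc1-c1cc(Oc2ccc(NC(=O)Nc3ccccc3C(F)(F)F)cc2F)ccn1`: 3410 nM in this assay.

Among the compounds with values here, compound 2 holds the higher of the two numbers; the single measured step, a 3.8-fold higher number from compound 1 to compound 2 (0.58 log units; beyond the scatter), separates them. Compound 3 `CCN(CC)CCn1cnnc1-c1cc(Oc2ccc(NC(=O)Nc3ccc(F)c(Cl)c3)cc2F)ccn1` differs from compound 2 by 3-chloro-4-fluorophenyl in place of 2-(trifluoromethyl)phenyl on an amide-type nitrogen. This largely undoes the change measured in a 3.8-fold higher number from compound 1 to compound 2 (0.58 log units; beyond the scatter), bringing the substitution pattern closer to that of compound 1 than to compound 2. Compound 3 is therefore expected to fall back toward compound 1 in this assay, by about a 2.3-fold lower number from compound 2 to compound 3 (0.36 log units; beyond the scatter), with an estimated 1500 nM and a range from 500 nM to 4500 nM.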

Compound 3, half-maximal inhibitory concentration: 500 nM
Compound 3: middle estimate off by 3.0-fold (0.48 log units), on the high side, and the stated range covers the measured number.
By their numbers in this assay, from the lowest: compounds 3 and 1 (each within the scatter of the next); then compound 2.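

In this assay the change to 3-chloro-4-fluorophenyl on the amide-type nitrogen gives a 6.8-fold lower number from compound 2 to compound 3 (0.83 log units; beyond the scatter) and so shows that a trifluoromethyl group is not needed at this position for the lower numbers seen here. Against the other aryl group it gives a 1.8-fold lower number from compound 1 to compound 3 (0.26 log units; within the scatter) and so leaves 3-chloro-4-fluorophenyl and 4-chloro-3-(trifluoromethyl)phenyl indistinguishable in this measurement. No measurement is available that accounts for these steps.

Still open, on these data alone, is how an amine or a carboxylic acid on this phenyl ring would fare in this assay.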